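A few compounds are considered here, and "the series" means these few. Any claim that something is new, unique, unknown or untested is made for them only; others in the source may bear on it.

Measured compounds:
compound 1, `COc1cc2cc(Oc3ccc(NC(=O)Nc4ccc(C(F)(F)F)cc4)cc3)c(C)nc2cc1OC`: 80.9%
compound 2, `COc1cc2cc(Oc3ccc(NC(=O)Nc4cccc(C(F)(F)F)c4)cc3)c(C)nc2cc1OC`: -8.32%

Among the measured compounds shown here, in a functional assay on MDA-MB-231 cells (Homo sapiens) for inhibition, read by sulforhodamine B assay, with a stated time of 48 h, tested at 10 uM (on this read-out higher numbers stand for a weaker effect at the one concentration tested and lower numbers for a stronger effect), compound 2 gives -8.32% and stands lowest of the two numbers; the one step measured, a number 89.2 percentage points lower from compound 1 to compound 2 (beyond the scatter), replaced 4-(trifluoromethyl)phenyl with 3-(trifluoromethyl)phenyl and is large. Compound 3, `COc1cc2cc(Oc3ccc(NC(=O)Nc4ccc(Cl)c(C(F)(F)F)c4)cc3)c(C)nc2cc1OC`, differs from compound 2 by chloro in place of hydrogen on an aromatic carbon — 3-(trifluoromethyl)phenyl becoming 4-chloro-3-(trifluoromethyl)phenyl. For the measured compounds named here, no measured step adds a chloro anywhere, so the only guidance is indirect: compound 3 keeps the 3-(trifluoromethyl)phenyl that sits in compound 2, the compound with the strong read-out. The step from compound 2 to compound 3 in this assay is therefore expected to stay within the scatter, with no clear direction. Compound 3 is estimated at 0%, within -20% to 30%, meaning an expected step of a number 8.3 percentage points higher from compound 2 to compound 3 (within the scatter).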

Compound 3, a percentage reported as activity, at one concentration (the size of the read-out at that concentration, not a potency): -50.6%
Estimate against measurement, compound 3: 50.6 percentage points above; measured number outside the range, below it.
By their numbers in this assay, from the lowest: compound 3; then compound 2; then compound 1.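

In this assay, chloro on the aromatic carbon ortho to the trifluoromethyl group and para to a large group has a clear effect of its own, with a number 42.3 percentage points lower from compound 2 to compound 3 (beyond the scatter), a large step towards a stronger effect. The earlier pair showed only that the place of the trifluoromethyl group matters; this step shows that the read-out of compound 2, already strong, can still go lower when a second group is added to that ring. With 4-chloro-3-(trifluoromethyl)phenyl in place of 4-(trifluoromethyl)phenyl, the result is a number 131.5 percentage points lower from compound 1 to compound 3 (beyond the scatter).

No evidence at hand explains these steps. Going by these compounds, it remains open whether fluoro, bromo or a methoxy group in place of the chloro would give a similar read-out, and whether a chloro at this place is needed for it.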